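Chlorothiophene swap on the pyridine core, second instance

The compounds below may be only part of what the source reports. "The series", "measured", "known", "first", "only" and "open" are said of these compounds alone.

Compound 1 `Cc1ccsc1-c1cc(-c2ccco2)cc(-c2ccc(Cl)cc2)n1` gives 1% in an assay on isolated protein for inhibition of DNA topoisomerase 1 (Homo sapiens), with a stated time of 30 min, tested at 100 uM; a higher number here means more inhibition at the concentration tested (going by the name of the read-out), a lower number less inhibition. Compound 2 `Clc1ccc(-c2cc(-c3ccco3)cc(-c3ccc(Cl)s3)n2)cc1` gives 53.1% in this assay, and the step of a number 52.1 percentage points higher from compound 1 to compound 2 (beyond the scatter) is 5-chlorothiophen-2-yl in place of 3-methylthiophen-2-yl on an aromatic carbon. Compound 3 `Cc1ccsc1-c1cc(-c2ccc(Cl)o2)cc(-c2ccco2)n1` gives 7.8% in this assay; the difference between the core of compound 3 and the core of compound 1 is not broken down here. Compound 4 `Clc1ccc(-c2cc(-c3ccco3)nc(-c3ccc(Cl)s3)c2)o1` is unmeasured; it differs from compound 3 by 5-chlorothiophen-2-yl in place of 3-methylthiophen-2-yl on an aromatic carbon. This is the same kind of change as that from compound 1 to compound 2, though around the place the group sits meta to a 5-chlorofuran-2-yl group rather than meta to a 4-chlorophenyl group. A large upward step is expected for compound 4, a number 37.2 percentage points higher from compound 3 to compound 4 (beyond the scatter), because the earlier step of a number 52.1 percentage points higher from compound 1 to compound 2 (beyond the scatter) was large, tempered by the changed surroundings. Compound 4 is estimated at 45%, between 15% and 75%.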

Compound 4, a percentage reported as inhibition, at one concentration (the size of the read-out at that concentration, not a potency): 23.1%
For compound 4 the middle estimate is 21.9 percentage points above the measured one, within the range that was stated.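

In this assay, 5-chlorothiophen-2-yl in place of 3-methylthiophen-2-yl on the second core gives a number 15.3 percentage points higher from compound 3 to compound 4 (beyond the scatter), so the direction of the change carries over between these two cores. The size of the step does not carry over: the same change on two cores in this assay, a number 52.1 percentage points higher (beyond the scatter) from compound 1 to compound 2 and a number 15.3 percentage points higher (beyond the scatter) from compound 3 to compound 4, 36.8 percentage points apart, beyond the scatter of two such steps. Two pairs cannot show which difference between the cores goes with the smaller step, or whether the direction holds on any further core.

Going by these compounds, it remains open what an unsubstituted thiophen-2-yl or a 5-bromothiophen-2-yl would give at this place, and what an amine or a carboxylic acid would do on either core. Readings at a single concentration also leave potency open.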